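Chloro for methoxy on the pendant aryl of the shared core

The source may hold more compounds than are shown below. What is called first, only, known or untested is meant among the compounds shown, and "the series" means these compounds.

Three compounds of this series carry measured numbers. Compound 1 `COc1ccc(-c2nsc3c2NC(=O)CC3c2cccc(OC)c2)cc1` gives 395 nM in a functional assay on MDA-MB-468 cells (Homo sapiens) for antiproliferative activity, read by sulforhodamine B assay, with a stated time of 48 h; on this read-out lower numbers stand for stronger inhibition and higher numbers for weaker inhibition. Compound 2 `COc1ccc(-c2nsc3c2NC(=O)CC3c2cccc(Cl)c2)cc1` gives 174 nM in this assay, and compound 3 `COc1ccc(-c2nsc3c2NC(=O)CC3c2ccsc2)cc1` gives 117 nM in this assay. The step from compound 1 to compound 2 is a 2.3-fold lower number from compound 1 to compound 2 (0.36 log units; beyond the scatter), the change being (chloro in place of methoxy on an aromatic carbon). The step from compound 1 to compound 3 is a 3.4-fold lower number from compound 1 to compound 3 (0.53 log units; beyond the scatter), with the change (thiophen-3-yl in place of 3-methoxyphenyl on a saturated ring carbon). Between compound 2 and compound 3 the step is a 1.5-fold lower number from compound 2 to compound 3 (0.17 log units; within the scatter), so these two compounds cannot be ordered.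

Compound 4 `O=C1CC(c2ccsc2)c2snc(-c3ccc(Cl)cc3)c2N1` has not yet been measured in this assay. It differs from compound 3 by chloro in place of methoxy on an aromatic carbon. Among the compounds with values here, this is the same kind of change as the one from compound 1 to compound 2, but not the same: there the chloro entered meta to a large group, here it enters para to a large group, on a different ring of the shared core. The cores of compound 1 and compound 3 differ by thiophen-3-yl in place of 3-methoxyphenyl on a saturated ring carbon, as given above.

The step from compound 3 to compound 4 in this assay is expected to be a 1.5-fold lower number from compound 3 to compound 4 (0.17 log units; within the scatter), smaller than the measured one, because a 2.3-fold lower number from compound 1 to compound 2 (0.36 log units; beyond the scatter) was obtained at a different place. The step from compound 2 to compound 3 lies within the scatter, which also speaks for a smaller step here. For compound 4 the estimated value in this assay is 80 nM, expected between 35 nM and 200 nM.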

Compound 4, half-maximal inhibitory concentration: 291 nM
Compound 4: middle estimate off by 3.6-fold (0.56 log units), on the low side, outside the stated range (above it).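

Chloro in place of methoxy, on an aromatic carbon of a six-membered aromatic ring of carbon only and para to a large group, gives a 2.5-fold higher number from compound 3 to compound 4 (0.40 log units; beyond the scatter) in this assay. A change of the same name therefore does not carry its direction from one core to the other in this series, and the two steps differ by more than the scatter allows: the same change on two cores in this assay, a 2.3-fold lower number (0.36 log units; beyond the scatter) from compound 1 to compound 2 and a 2.5-fold higher number (0.40 log units; beyond the scatter) from compound 3 to compound 4, 5.6-fold (0.75 log units) apart, beyond the scatter of two such steps

This does not show what sets the two steps apart, since the pairs differ both in the ring that bears the change and in the group on the saturated ring carbon, and no pair shown separates these two differences; two pairs also give no rule for any other core in the series.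

Open, going by these compounds, is whether a fluoro, a methyl or a hydroxyl in the place the methoxy leaves in compound 3 would stay close to compound 3 or move towards compound 4, and whether the same exchange on the core of compound 1, at the place used in compound 4, would raise the number too. Also open, on these data alone, is how the series responds to an amine or a carboxylic acid on the saturated ring carbon in place of thiophen-3-yl.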